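Two anilides at the limit and a hydroxy-bromo analogue

A few compounds are considered here, and "the series" means these few. Any claim that something is new, unique, unknown or untested is made for them only; others in the source may bear on it.

Measured compounds:
compound 1 `O=C(Nc1ccc(Sc2nc3ccccc3s2)cc1)c1cc(Br)cc(Br)c1` — in an assay for inhibition of HSP60/HSP10 (Homo sapiens), with a stated time of 60 min (a higher number here means a weaker inhibitor, a lower number a stronger inhibitor), compound 1 gives > 100000 nM, a limit of the assay.
compound 2 `COc1ccccc1C(=O)Nc1cccc(Cl)c1` — in this assay compound 2 gives > 100000 nM, also a limit.

For compound 1 the assay gives only a limit and no number. This is the common picture here, since the limit of > 100000 nM in this assay, at which 2 of the 2 values shown sit, holds for every value shown; nothing separates compound 1 from compound 2 on these numbers, and no ordering between them can be read.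

Compound 3 `O=C(Nc1ccc(Sc2nc3ccccc3s2)cc1)c1cccc(Br)c1O` differs from compound 1 in one place: 3-bromo-2-hydroxyphenyl in place of 3,5-dibromophenyl on a carbonyl carbon. Within the data shown here, no step between measured compounds is known, so nothing in the data tells how this change should act in this assay. Because the value of compound 1 is > 100000 nM, a limit, any step from it could be hidden entirely, and the expected step of an at least 1.6-fold lower number from compound 1 to compound 3 (0.22 log units; that floor lies within the scatter) is given with that uncertainty.

For compound 3 the expectation in this assay is 60000 nM, estimated to lie between 10000 nM and 300000 nM, with a fair chance that again only a limit is reported.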

Compound 3, half-maximal inhibitory concentration: 26000 nM
The estimate for compound 3 lay 2.3-fold (0.36 log units) above the measured number; low and high end bracket the measured number.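

In this assay the exchange of 3,5-dibromophenyl for 3-bromo-2-hydroxyphenyl on a carbonyl carbon gives an at least 3.8-fold lower number from compound 1 to compound 3 (0.58 log units; beyond the scatter) and so brings the first measured number into the series. The group on this carbonyl carbon, whose other neighbour is an amide-type nitrogen, is therefore a place where one change with the rest of compound 1 held constant can move the read-out beyond the scatter, which the two earlier compounds could not show while both stood at a limit. The printed step is only a floor and its full size remains unknown, because compound 1 gives a limit rather than a number: the limit of > 100000 nM in this assay, at which 2 of the 3 values shown sit.

The change also counts one bromine fewer, adds one oxygen and brings in a hydrogen-bond donor and acceptor, and the compounds shown do not separate these parts, so it stays open whether the hydroxy group, the loss of the second bromine or both together account for the step. From the compounds shown here alone, it is equally open whether an amine or a carboxylic acid on the same ring would give a number in this assay or return to the limit.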